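Trifluoromethyl for methoxy in a urotensin-2 receptor agonist series

This account rests on a few compounds, and the source may have more. Where it says the series, first, only, none or still open, it means among the compounds named here.

Three compounds sharing a dimethylaminopropyl amide core were characterised in a functional assay on NIH3T3 cells for agonist activity at Urotensin-2 receptor (Homo sapiens), with a stated time of 5 days; on this read-out higher numbers stand for larger maximal responses and lower numbers for smaller maximal responses. Compound 1 `COc1ccc(CCC(=O)NC(CCN(C)C)c2ccc3ccccc3c2)cc1` gives 113% in this assay. Compound 3 `CN(C)CCC(NC(=O)/C=C/c1ccccc1)c1ccc2ccccc2c1` gives 116%, a number within the scatter of that of compound 1. Compound 2 `COc1ccc(/C=C/C(=O)NC(CCN(C)C)c2ccc(C)cc2)cc1` gives 79%, which lies beyond the scatter below compound 1. Compound 1 therefore stands second highest of the three numbers, close to compound 3 and well above compound 2.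

Compound 4 `CN(C)CCC(NC(=O)CCc1ccc(C(F)(F)F)cc1)c1ccc2ccccc2c1` has not been measured in this assay. It differs from compound 1 in one place: trifluoromethyl in place of methoxy on an aromatic carbon. Among the measured compounds shown here, no measured pair in the set shows the effect of this exchange, so the expectation rests on the range spanned by compounds 1 and 3, whose numbers agree within the scatter, and on the lower number of compound 2. Since the naphthyl portion and the saturated amide linker of compound 1 are kept, no step beyond the scatter in either direction is expected. For compound 4 the expected efficacy in this assay is 105%, with a range from 80% to 125%. This corresponds to an expected step of a number 8 percentage points lower from compound 1 to compound 4 (within the scatter).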

Compound 4, largest response reached (reported as efficacy), in percent of the reference or control that the assay uses: 75%
Compound 4: the middle estimate sits 30 percentage points above what was measured, outside the stated range (below it).
By their numbers in this assay, from the lowest: compounds 4 and 2 (each within the scatter of the next); then compounds 1 and 3 (each within the scatter of the next).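

In this assay the exchange of methoxy for trifluoromethyl, on an aromatic carbon para to a large group, gives a number 38 percentage points lower from compound 1 to compound 4 (beyond the scatter) and so shows that the group at this position bears on the maximal response while the rest of compound 1 stays unchanged. The earlier compounds shown here could not show this, as no two of them differed in one place only, and none offered a view of this position on its own. Nothing at hand bears on what lies behind this step.

The compounds shown leave open whether the step belongs to the arrival of trifluoromethyl or to the loss of methoxy, a question that plain hydrogen, a hydroxyl, a chlorine or a nitrile at the same place could help to settle. They also leave open whether 4-methoxyphenyl to 4-(trifluoromethyl)phenyl gives a step of similar size on the core of compound 2, which carries the same methoxy but differs elsewhere from compound 1.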